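Acyl sulfamate nucleosides: a chain swap on compound 1

A few compounds are considered here, and "the series" means these few. Any claim that something is new, unique, unknown or untested is made for them only; others in the source may bear on it.

Compound 1 `CO[C@H](C(=O)NS(=O)(=O)OC[C@H]1O[C@@H](n2cnc3c(N)nc(Cl)nc32)[C@H](O)[C@@H]1O)[C@H](OC)C(C)C` is known in a functional assay on HCT-116 cells (Homo sapiens) for antiproliferative activity, read by sulforhodamine B assay, with a stated time of 72 h (a higher number here means a weaker inhibitor, a lower number a stronger inhibitor), only as a limit, > 20000 nM, and no number stands for it (the limit of > 20000 nM in this assay, at which 1 of the 2 values shown sits). Compound 2 `Nc1ncnc2c1ncn2[C@@H]1O[C@H](COS(=O)(=O)NC(=O)[C@@H](O)[C@H](O)C2CC2)[C@@H](O)[C@@H]1O` gives 9140 nM in this assay. Compound 3 `CC(C)C[C@H](Cl)C(=O)NS(=O)(=O)OC[C@H]1O[C@@H](n2cnc3c(N)nc(Cl)nc32)[C@H](O)[C@@H]1O` differs from compound 1 by a group of 6 heavy atoms (5 carbon, 1 chlorine; no ring) in place of a group of 9 heavy atoms (7 carbon, 2 oxygen; no ring), on a carbonyl carbon. Going by the values given here, no step between measured compounds is available, so the direction of this change cannot be read from earlier pairs; only a modest shift in this assay is expected, and the expected step is an at least 1.3-fold lower number from compound 1 to compound 3 (0.12 log units; that floor lies within the scatter). Compound 3 is estimated at 15000 nM, with a range from 4000 nM to 60000 nM.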

Compound 3, half-maximal inhibitory concentration: 7510 nM
For compound 3 the middle estimate is 2.0-fold (0.30 log units) above the measured one, within the range that was stated.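

Working notes: in this assay the swap on the carbonyl carbon gives an at least 2.6-fold lower number from compound 1 to compound 3 (0.42 log units; beyond the scatter) and is the first readable step at this position. The group of 6 heavy atoms, which carries chlorine, therefore replaces the group of 9 heavy atoms, which carries two oxygens, with stronger inhibition beyond the scatter. Compound 1 stands only as a limit, so the step has a lower bound and no fixed size: the limit of > 20000 nM in this assay, at which 1 of the 3 values shown sits.

Whether the chlorine or the rest of the chain accounts for the step remains open. An amine in place of the chlorine, or a longer chain, would bear on this.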